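Moving the bromine: from compound 1 to compound 3

A few compounds are considered here, and "the series" means these few. Any claim that something is new, unique, unknown or untested is made for them only; others in the source may bear on it.

Measured so far:
compound 1 `COc1ccc(/C=C/c2cc(OC)cc(OC)c2/C=C/C(=O)c2cc3ccc(Br)cc3oc2=O)cc1` — 55300 nM
compound 2 `CCOc1cccc2cc(C(=O)/C=C/c3c(/C=C/c4ccc(OC)cc4)cc(OC)cc3OC)c(=O)oc12` — > 60000 nM

Among the measured compounds shown here, in an assay on isolated protein for inhibition of Amine oxidase [flavin-containing] B (Homo sapiens), read by fluorescence, with a stated time of 15 min (on this read-out lower numbers stand for stronger inhibition and higher numbers for weaker inhibition), compound 1 gives 55300 nM, and this is the only actual number in the set. Compound 2 is reported only as a limit of the assay, giving > 60000 nM in this assay, which is the limit of > 60000 nM in this assay, at which 1 of the 2 values shown sits. For the measured compounds named here, no pair of measured compounds differs in a single place, so no measured step is available to anchor a change.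

Compound 3 `COc1ccc(/C=C/c2cc(OC)cc(OC)c2/C=C/C(=O)c2cc3cc(Br)ccc3oc2=O)cc1` is the next candidate. It differs from compound 1 by a group of 12 heavy atoms (9 carbon, 2 oxygen, 1 bromine; one six-membered aromatic ring of carbon only, one six-membered aromatic ring with 1 hetero atom) in place of a group of 12 heavy atoms (9 carbon, 2 oxygen, 1 bromine; one six-membered aromatic ring of carbon only, one six-membered aromatic ring with 1 hetero atom), on a carbonyl carbon. Going by the values given here, both weak values so far suggest the series sits near the top of the measurable window. The step from compound 1 to compound 3 is expected to be none beyond the usual scatter, that is a 1.0-fold lower number from compound 1 to compound 3 (0.00 log units; within the scatter). Compound 3 is therefore estimated at 55000 nM, within 20000 nM to 150000 nM, with a real chance that this assay returns only a limit.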

Compound 3, half-maximal inhibitory concentration: > 60000 nM
Compound 3 ended at the assay's limit (the forecaster's own chance of this, stated with the estimate: 40%); middle value at least 1.0-fold (0.03 log units) away from the limit.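

In this assay compound 3 gives > 60000 nM as a limit of the assay, not a number. Moving the bromine within the group on the carbonyl carbon gives an at least 1.0-fold higher number from compound 1 to compound 3 (0.03 log units; that floor lies within the scatter) and so provides the first single-place step in the series, but its floor shows no change that can be told from scatter, and the true size of the step remains unknown. Most of the set now rests at the assay's limit: the limit of > 60000 nM in this assay, at which 2 of the 3 values shown sit.

Still open, from the compounds shown here alone, is whether an amine or a carboxylic acid in place of the bromine would bring a value clear of that limit. Also open, going by these compounds, is whether a longer chain in place of the methoxy groups on the shared core would shift the read-out at all.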